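A few compounds are considered here, and "the series" means these few. Any claim that something is new, unique, unknown or untested is made for them only; others in the source may bear on it.

Measured so far in an ADME assay on microsomes from liver (Homo sapiens) for metabolic stability, read by LC-MS, with a stated time of 30 min, tested at 0.1 uM; on this read-out higher numbers stand for a more stable compound and lower numbers for a less stable compound
- compound 1 `FC(F)(F)c1ccc(Nc2cc3[nH]c(-c4cccc(C(F)(F)F)c4)nc3cn2)nc1` gives 90%
- compound 2 `Fc1ccc(-c2nc3cnc(Nc4ccc(C(F)(F)F)cn4)cc3[nH]2)cc1F` gives 88%
- compound 3 `FC(F)(F)c1ccc(Nc2cc3[nH]c(C4CC4)nc3cn2)nc1` gives 97%

Compound 3, at 97%, stands level with the other two compounds, since all three values lie within the usual scatter of one another.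

The next compound is compound 4 `FC1(F)CCC(c2nc3cnc(Nc4ccc(C(F)(F)F)cn4)cc3[nH]2)CC1`, which carries 4,4-difluorocyclohexyl in place of cyclopropyl on an aromatic carbon, between two ring nitrogen atoms (4,4-difluorocyclohexyl in place of cyclopropyl on an aromatic carbon).

Three measured steps exchange the group at this same place: a number 2 percentage points lower from compound 1 to compound 2 (within the scatter), a number 7 percentage points higher from compound 1 to compound 3 (within the scatter) and a number 9 percentage points higher from compound 2 to compound 3 (within the scatter). None of them goes beyond the scatter, so no clear step is expected in this assay here either. Among the measured compounds shown here, still, no measured compound carries a six-membered non-aromatic ring at this place, so the range is kept wide, mostly on the lower side.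

The expected change is a number 7 percentage points lower from compound 3 to compound 4 (within the scatter), which would stay small.

For compound 4 the estimated value is 90%, with an expected range from 77% to 98%.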

Compound 4, percent of the compound remaining: 99%
Beside the measured number, compound 4's estimate is 9 percentage points below it, and the stated range ends below it.
By their numbers in this assay, from the lowest: compounds 2, 1, 3 and 4 (each within the scatter of the next, the first and the last beyond it).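

In this assay, a much bigger group fits this position without a clear loss: cyclopropyl, with 3 heavy atoms, gives way to 4,4-difluorocyclohexyl, with 8, and the result is a number 2 percentage points higher from compound 3 to compound 4 (within the scatter). Against the aromatic groups the picture is mixed, since the exchange for 3,4-difluorophenyl gives a number 11 percentage points higher from compound 2 to compound 4 (beyond the scatter), the first step at this position beyond the scatter, though a modest one, whereas the exchange for 3-(trifluoromethyl)phenyl gives a number 9 percentage points higher from compound 1 to compound 4 (within the scatter). No supporting measurement explains these numbers.

Plain cyclohexyl is absent from the compounds shown, so the part played by the two fluorine atoms stays open. Going by these compounds, it is also open how the read-out would respond at this position to a ring bearing an amine, a carboxylic acid or a longer alkyl chain.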